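Chloro on the 1,3-benzothiazol-2-yl Group of Compound 3

A few compounds are considered here, and "the series" means these few. Any claim that something is new, unique, unknown or untested is made for them only; others in the source may bear on it.

Measured so far in a functional assay on HeLa cells (Homo sapiens) for antiproliferative activity, read by MTT assay, with a stated time of 48 h; on this read-out lower numbers stand for stronger inhibition and higher numbers for weaker inhibition:
compound 1, `Oc1ccc2ccccc2c1C(Nc1nc2ccccc2s1)c1cn(-c2ccccc2)nc1-c1ccccc1`, gives 17300 nM
compound 2, `COc1ccc(-c2nn(-c3ccccc3)cc2C(Nc2nc3ccccc3s2)c2c(O)ccc3ccccc23)cc1`, gives 9340 nM
compound 3, `O=[N+]([O-])c1ccc(-c2nn(-c3ccccc3)cc2C(Nc2nc3ccccc3s2)c2c(O)ccc3ccccc23)cc1`, gives 6810 nM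

Compound 3 has the lowest number of the three. Its nearest neighbour is compound 2, the step being a 1.4-fold lower number from compound 2 to compound 3 (0.14 log units; within the scatter), which sits within the scatter; its furthest is compound 1, with a 2.5-fold lower number from compound 1 to compound 3 (0.40 log units; beyond the scatter), a modest step beyond the scatter. The remaining step, a 1.9-fold lower number from compound 1 to compound 2 (0.27 log units; within the scatter), also lies within the scatter.

Compound 4, `O=[N+]([O-])c1ccc(-c2nn(-c3ccccc3)cc2C(Nc2nc3ccc(Cl)cc3s2)c2c(O)ccc3ccccc23)cc1`, differs from compound 3 in one place: chloro in place of hydrogen on an aromatic carbon. None of the three measured steps touches the (1,3-benzothiazol-2-yl)amino part of the shared core; each of them concerns a substituent elsewhere in the molecule, and each is small. For the measured compounds named here, there is therefore no measured step that bears directly on this change, and no ground for expecting a step beyond the scatter in this assay . Compound 4 is expected to give about 5500 nM, likely between 2500 nM and 12000 nM, which would be an estimated step of a 1.2-fold lower number from compound 3 to compound 4 (0.09 log units; within the scatter).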

Compound 4, half-maximal inhibitory concentration: 13400 nM
Compound 4: middle estimate off by 2.4-fold (0.39 log units), on the low side; measured number outside the range, above it.
By their numbers in this assay, from the lowest: compounds 3, 2, 4 and 1 (each within the scatter of the next, the first and the last beyond it).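

This is the first change shown on the 1,3-benzothiazol-2-yl group, and in this assay chloro in place of hydrogen on this group gives a 2.0-fold higher number from compound 3 to compound 4 (0.29 log units; within the scatter). The position therefore accepts a chloro without a step beyond the scatter, and the read-out shows no gain from this group that can be separated from the variation between repeated measurements. Nothing available here accounts for the size of this step.

A single chloro leaves open how other groups would read at this position, such as fluoro, an amine or a carboxylic acid. Going by these compounds, it also remains open whether the same chloro would give a similar step on compound 1 or compound 2, which carry hydrogen and methoxy where compound 3 carries nitro.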